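The compounds below may be only part of what the source reports. "The series", "measured", "known", "first", "only" and "open" are said of these compounds alone.

Measured compounds in this series:

Compound 1 `C=CC1=C(C(=O)NCc2ccc(C)cc2)C(c2ccc(OC)c(OC)c2)OC1`: > 100000 nM
Compound 2 `C=CC1=C(C(=O)NCc2ccccc2)C(c2ccc(OC)cc2)OC1`: > 100000 nM
Compound 3 `C=CC1=C(C(=O)Nc2ccccc2)C(c2ccc(OC)c(OC)c2)OC1`: > 100000 nM

All three values in a functional assay on A549 cells (Homo sapiens) for cytotoxicity, read by MTT assay, with a stated time of 24 h (on this read-out lower numbers stand for stronger inhibition and higher numbers for weaker inhibition), are limits of the assay, not numbers. Compound 3 gives only a limit, > 100000 nM, so its position cannot be placed relative to the other two beyond the fact that every value shown sits at the same limit, as the limit of > 100000 nM in this assay, at which 3 of the 3 values shown sit, states.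

Among the measured compounds shown here, the one single-point step among the measured compounds, a step that the two limits leave unreadable from compound 1 to compound 3, runs between two limits and its size is not readable. It shows only that the anilide and the 4-methylbenzylamide both stay out of range.

The not yet measured compound 4 `C=CC1=C(C(=O)NCc2ccccc2)C(c2ccc(OC)c(OC)c2)OC1` differs from compound 3 by benzyl in place of phenyl on an amide-type nitrogen, that is, anilino becomes benzylamino. Compound 1 and compound 2 already carry a benzylamino-type amide and both sit at the limit, so the change brings no sign of a gain.

The expected step is a step that the limit leaves unreadable from compound 3 to compound 4, none beyond the scatter, with the result most likely reported again as a limit. Compound 4 is therefore estimated at 150000 nM, with a range from 80000 nM to 500000 nM.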

Compound 4, half-maximal inhibitory concentration: > 100000 nM
Compound 4 was reported as a limit (the forecaster's own chance of this, stated with the estimate: 85%); the middle value lies beyond the limit too.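

Compound 4 gives > 100000 nM, a limit of the assay. Among the compounds shown here, the steps to it from compound 1, compound 2 and compound 3 cannot be read, and no new step follows: the limit of > 100000 nM in this assay, at which 4 of the 4 values shown sit. The compounds shown leave open which change to the shared core, if any, would give a number rather than a limit in this assay.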